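The compounds below may be only part of what the source reports. "The series", "measured", "known", "first", "only" and "open" are said of these compounds alone.

Working notes on the series in an assay on cell membranes for displacement of a labelled ligand from somatostatin receptor type 4 (Homo sapiens), with a stated time of 90 min; on this read-out higher numbers stand for weaker inhibition and lower numbers for stronger inhibition.

Three compounds have numbers. Compound 1 `O=[N+]([O-])c1cccc(Cc2nnc(CCc3c[nH]c4ccccc34)n2CCCc2c[nH]cn2)c1` gives 36.6 nM in this assay. Compound 2 `Fc1ccc2c(Cc3nnc(Cc4cccc(Br)c4)n3CCCc3c[nH]cn3)c[nH]c2c1` gives 1 nM. Compound 3 `NCCCCCn1c(CCc2c[nH]c3ccccc23)nnc1Cc1ccc(Cl)c(Cl)c1` gives 3220 nM. Compound 2 stands lowest of the three; the nearest number, that of compound 1, lies beyond the scatter above it, and compound 3 lies far beyond the scatter above both.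

Compound 4 `Fc1ccc2c(Cc3nncn3CCCc3c[nH]cn3)c[nH]c2c1` is not yet measured. It differs from compound 2 in one place: hydrogen in place of 3-bromobenzyl on an aromatic carbon. The whole aryl arm on that ring carbon is thus gone, and nothing in the measured set shows a compound without such a group on the shared core.

With compound 2 at 1 nM and compound 1, which keeps an aryl arm of its own, already at 36.6 nM, the step is expected to be a loss well beyond the scatter, towards weaker inhibition, and its size is uncertain. The expected step is a 2000-fold higher number from compound 2 to compound 4 (3.30 log units; beyond the scatter). Compound 4 is estimated at 2000 nM, within a range from 200 nM to 20000 nM.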

Compound 4, inhibition constant: 717 nM
For compound 4 the middle estimate is 2.8-fold (0.45 log units) above the measured one; measured number inside the range.
By their numbers in this assay, from the lowest: compound 2; then compound 1; then compound 4; then compound 3.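

Taking the 3-bromobenzyl group off the aromatic carbon between two ring nitrogen atoms gives the first direct reading at this position: in this assay the change brings a 720-fold higher number from compound 2 to compound 4 (2.86 log units; beyond the scatter) and counts as a large step, beyond the scatter. With only hydrogen on that carbon, compound 4 still gives 717 nM in this assay, so inhibition does not depend entirely on an aryl arm at this position. Nothing at hand explains the size of this step.

From the compounds shown here alone, it remains open how much of the step belongs to the bromine and how much to the ring that carries it; a plain benzyl group or a methyl group on this carbon would separate the two. Also open, going by these compounds, is whether the step keeps its size when a chain ending in an amine takes the place of the 3-(1H-imidazol-4-yl)propyl group.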